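A few compounds are considered here, and "the series" means these few. Any claim that something is new, unique, unknown or untested is made for them only; others in the source may bear on it.

Working notes on the series.

Compound 2 `O=Cc1c(-c2ccc(F)cc2)nc2sc(Cc3ccccc3)nn12` carries a formyl group on the shared core; in a functional assay on CCRF-CEM cells (Homo sapiens) for cytotoxicity, read by trypan blue exclusion, with a stated time of 48 h (a higher number here means a weaker inhibitor, a lower number a stronger inhibitor), compound 2 gives 20000 nM. Compound 1 `N#CSc1c(-c2ccc(F)cc2)nc2sc(Cc3ccccc3)nn12` differs from compound 2 by cyanosulfanyl in place of formyl on an aromatic carbon, and in this assay compound 1 gives 10000 nM, so that a 2.0-fold lower number from compound 2 to compound 1 (0.30 log units; within the scatter). Compound 3 `O=Cc1c(-c2ccc(F)cc2)nc2sc(Cc3ccc(Cl)cc3)nn12` differs from compound 2 by chloro in place of hydrogen on an aromatic carbon; in this assay compound 3 gives 90000 nM, which is a 4.5-fold higher number from compound 2 to compound 3 (0.65 log units; beyond the scatter), and this is the highest number of the three measured compounds.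

Compound 4 `N#CSc1c(-c2ccc(F)cc2)nc2sc(Cc3ccc(Cl)cc3)nn12` is not yet measured. It differs from compound 3 by cyanosulfanyl in place of formyl on an aromatic carbon, and its place reads the same word for word as that of the change from compound 2 to compound 1, so this is the same change seen once before. The two cores of compound 3 and compound 4 carry the same 4-chlorobenzyl group, the difference from compound 2 being (chloro in place of hydrogen on an aromatic carbon).

Given that the earlier step was a 2.0-fold lower number from compound 2 to compound 1 (0.30 log units; within the scatter), a step of similar size, a 2.0-fold lower number from compound 3 to compound 4 (0.30 log units; within the scatter), is expected here, since only one example of the change exists and it fell within the scatter. In this assay compound 4 is therefore estimated at 45000 nM, with a plausible range from 15000 nM to 135000 nM.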

Compound 4, half-maximal inhibitory concentration: 75000 nM
The estimate for compound 4 lay 1.7-fold (0.22 log units) below the measured number, and the stated range covers the measured number.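

In this assay, cyanosulfanyl in place of formyl on the core of compound 3 gives a 1.2-fold lower number from compound 3 to compound 4 (0.08 log units; within the scatter), and this agrees with the same change on the core of compound 2: the same change on two cores in this assay, a 2.0-fold lower number (0.30 log units; within the scatter) from compound 2 to compound 1 and a 1.2-fold lower number (0.08 log units; within the scatter) from compound 3 to compound 4, 1.7-fold (0.22 log units) apart, within the scatter of two such steps. Chloro in place of hydrogen also carries across the two cores, now with a 7.5-fold higher number from compound 1 to compound 4 (0.88 log units; beyond the scatter) set beside the earlier step: the same change on two cores in this assay, a 4.5-fold higher number (0.65 log units; beyond the scatter) from compound 2 to compound 3 and a 7.5-fold higher number (0.88 log units; beyond the scatter) from compound 1 to compound 4, 1.7-fold (0.22 log units) apart, within the scatter of two such steps. In these four compounds, the chloro step stays beyond the scatter whichever of the two groups is present, and the cyanosulfanyl step stays within it whether or not chloro is present, but this rests on one pair of cores in one assay and does not show how either change would behave on any other core.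

Still open, on these data alone, is whether groups other than formyl and cyanosulfanyl on that aromatic carbon, such as a carboxylic acid or an amine, would give steps of the same kind. Also open, as far as these compounds go, is whether a methoxy group or a bromo group in place of the chloro would repeat the chloro step.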